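Bulkier Amide Substituent on an Inactive Sulfonyl Series

This account rests on a few compounds, and the source may have more. Where it says the series, first, only, none or still open, it means among the compounds named here.

This set rests on a shared core carrying sulfonyl groups, and its members were tested in a functional assay on MIA PaCa-2 cells (Homo sapiens) for inhibition, read by MTT assay, with a stated time of 3 days; a higher number here means a weaker inhibitor, a lower number a stronger inhibitor. Compound 1 `CCOC(=O)[C@@H]1CCC[C@H](S(=O)(=O)c2ccc(S(=O)(=O)N(CC)CC)cc2)C1` gives only a limit, > 10000 nM. Compound 3 `CCOC(=O)[C@@H]1CCCN(S(=O)(=O)c2ccc(S(=N)(=O)N(CC)CC)cc2)C1` likewise gives only a limit, > 10000 nM. Compound 2 `CCN(CC)S(=O)(=O)c1ccc(S(=O)(=O)N2CCC[C@@H](C(=O)N(C)C(C)C)C2)cc1` also stands at a limit, > 10000 nM. Among the compounds with values here, every value recorded so far is therefore a limit rather than a number, as the limit of > 10000 nM in this assay, at which 3 of the 3 values shown sit, shows, and no compound can be ranked above or below another; compound 2 sits level with the rest.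

Compound 4 `CCN(CC)S(=O)(=O)c1ccc(S(=O)(=O)N2CCC[C@@H](C(=O)NC3CN(C(=O)NC(C)(C)C)C3)C2)cc1` differs from compound 2 in one place: (1-((tert-butyl)carbamoyl)azetidin-3-yl)amino in place of isopropyl(methyl)amino on a carbonyl carbon. Within the data shown here, since no measured step from compound 2 to another compound exists in this assay, the expectation rests on the three limits alone. Three inactive neighbours give no sign that a change on the amide nitrogen would bring inhibition into the measurable range. The step that the limit leaves unreadable from compound 2 to compound 4 is therefore estimated to be none beyond the scatter. The estimate for compound 4 in this assay is 20000 nM, with a range from 5000 nM to 100000 nM, and it is most likely that only a limit will again be reported for compound 4.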

Compound 4, half-maximal inhibitory concentration: > 10000 nM
Compound 4 was reported as a limit (the forecaster's own chance of this, stated with the estimate: 85%); the middle value does not contradict the limit.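

In this assay compound 4 gives > 10000 nM as a limit and not a number. Compound 2 also stands only at a limit, so no step can be read from one compound to the other. The compounds shown leave open whether any change to the shared core can bring inhibition into the measurable range.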